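Cytotoxicity notes: aryl carbonyl change from compound 3 to compound 4

The compounds below may be only part of what the source reports. "The series", "measured", "known", "first", "only" and "open" are said of these compounds alone.

The series shares a core carrying a phthalimide-ethyl thiocarbamate, varied at the aryl group on a carbonyl carbon. Compound 1 `Cc1ccc(C(=O)N(C(=S)OCCN2C(=O)c3ccccc3C2=O)c2ccc(Cl)cc2)cc1` sits at a limit of the assay: in an ADME assay on MT4 cells (Homo sapiens) for cytotoxicity, read by MTT assay (a higher number here means that more compound is tolerated, a lower number that less compound is tolerated), compound 1 gives > 100000 nM, which is a limit and not a number (the limit of > 100000 nM in this assay, at which 1 of the 3 values shown sits). Compound 2 `O=C1c2ccccc2C(=O)N1CCOC(=S)N(C(=O)c1ccc(Cl)c([N+](=O)[O-])c1)c1ccccc1` gives 51000 nM in this assay. Compound 3 `O=C1c2ccccc2C(=O)N1CCOC(=S)N(C(=O)c1ccc(F)c(F)c1)c1ccc(Cl)cc1` gives 52000 nM in this assay, the highest of the two numbers recorded, with compound 2 within the scatter of it.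

Compound 4 `Cc1cc(C(=O)N(C(=S)OCCN2C(=O)c3ccccc3C2=O)c2ccc(Cl)cc2)ccc1Br` is not yet measured. It differs from compound 3 by 4-bromo-3-methylphenyl in place of 3,4-difluorophenyl on a carbonyl carbon. The one measured step at this position, an at least 1.9-fold lower number from compound 1 to compound 3 (0.28 log units; that floor lies within the scatter), has a floor within the scatter, so no step beyond the scatter has been shown for changes on this aryl group. Within the data shown here, the exchange in compound 4 has no direct counterpart among the measured pairs. A step of a 1.0-fold lower number from compound 3 to compound 4 (0.02 log units; within the scatter) is therefore expected, essentially none beyond the scatter. Compound 4 is estimated at 50000 nM in this assay, within 20000 nM to 110000 nM.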

Compound 4, half-maximal cytotoxic concentration: 18000 nM
Beside the measured number, compound 4's estimate is 2.8-fold (0.44 log units) above it, outside the stated range (below it).
By their numbers in this assay, from the lowest: compound 4; then compounds 2 and 3 (each within the scatter of the next). At a limit, above all of these: compound 1.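

In this assay, the aryl group on the carbonyl carbon now shows a step beyond the scatter, which the earlier floor at this position did not: a 2.9-fold lower number from compound 3 to compound 4 (0.46 log units; beyond the scatter), with 4-bromo-3-methylphenyl in place of 3,4-difluorophenyl. The change from 4-methylphenyl to 4-bromo-3-methylphenyl points the same way, with an at least 5.5-fold lower number from compound 1 to compound 4 (0.74 log units; beyond the scatter), and this step is only a floor: the limit of > 100000 nM in this assay, at which 1 of the 4 values shown sits. So tolerance in this assay does shift with the substituents on this aryl group, and 4-bromo-3-methylphenyl gives the lowest number among the compounds that differ only here.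

The compounds shown do not separate the contribution of the bromine from that of the added methyl, as a plain 4-bromophenyl group stands in none of them. Going by these compounds, how an amine or a carboxylic acid on this aryl group would read in this assay also stays open.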